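Adding fluoro to the 3-cyanophenyl group of compound 2

The compounds below may be only part of what the source reports. "The series", "measured", "known", "first", "only" and "open" are said of these compounds alone.

Notes on the series in an in vitro ADME assay on microsomes from liver (Homo sapiens) for metabolic stability (on this read-out lower numbers stand for slow clearance and higher numbers for fast clearance), so far cover two compounds. Compound 1 (`CC(C)NC(=O)[C@H]1CC[C@@H](n2/c(=N/C(=O)c3ccc(F)cc3)[nH]c3ccc(CN4CCCCC4)cc32)CC1`) gives 302 mL.min-1.g-1 in this read-out. Compound 2 (`CC(C)NC(=O)[C@H]1CC[C@@H](n2/c(=N/C(=O)c3cccc(C#N)c3)[nH]c3ccc(CN4CCC(C(C)(C)O)CC4)cc32)CC1`) gives 72 mL.min-1.g-1 and holds the lower of the two numbers, with a gap beyond the scatter. Within the data shown here, these two compounds differ in more than one place, so their gap says nothing about any single group, and no step at one place has been measured yet.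

Compound 3 (`CC(C)NC(=O)[C@H]1CC[C@@H](n2/c(=N/C(=O)c3cc(F)cc(C#N)c3)[nH]c3ccc(CN4CCC(C(C)(C)O)CC4)cc32)CC1`) departs from compound 2 at one place only (fluoro in place of hydrogen on an aromatic carbon) with fluoro in place of hydrogen on an aromatic carbon, meta to a cyano group, so that 3-cyanophenyl becomes 3-cyano-5-fluorophenyl. Among the measured compounds shown here, the data hold no precedent for this change, so no direction can be argued, and no step beyond the scatter is expected in this assay for now. The expectation takes compound 2 at 72 mL.min-1.g-1 as its anchor. The estimated step (a 1.0-fold lower number from compound 2 to compound 3 (0.01 log units; within the scatter)) is expected to be negligible. For compound 3 the estimate is 70 mL.min-1.g-1 with an expected range from 35 mL.min-1.g-1 to 140 mL.min-1.g-1 pending measurement.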

Compound 3, intrinsic clearance in microsomes: 90 mL.min-1.g-1
For compound 3 the middle estimate is 1.3-fold (0.11 log units) below the measured one, and the stated range covers the measured number.
By their numbers in this assay, from the lowest: compounds 2 and 3 (each within the scatter of the next); then compound 1.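

In this assay the series now has its first step at a single place, a 1.3-fold higher number from compound 2 to compound 3 (0.10 log units; within the scatter), and it lies within the scatter, so compound 2 and compound 3 cannot be told apart on this read-out. Among these compounds, this position on the aromatic ring, meta to a cyano group, therefore accepts fluoro in place of hydrogen with no resolved shift in the read-out, and 3-cyano-5-fluorophenyl reads as 3-cyanophenyl does in this one matched pair, which the earlier compounds, differing in more than one place, could not show. Nothing measured bears on why the pair reads this way.

From the compounds shown here alone, one matched pair says nothing about larger replacements at this position, so it remains open whether a chloro, methyl, methoxy or amine group on the same carbon would also stay within the scatter of compound 2. Going by these compounds, it also remains open whether fluoro would give the same result with the cyano group exchanged for another group, such as a carboxylic acid, or in the setting of a different amine on the shared core.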